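Swapping the Acid Arm of Compound 1 for a Cyclopropyl Hydroxamate

A few compounds are considered here, and "the series" means these few. Any claim that something is new, unique, unknown or untested is made for them only; others in the source may bear on it.

Measured so far:
compound 1 `O=C(O)/C=C/c1ccc(NCc2cccc(Oc3ccccc3)c2)cc1` — 145 nM
compound 2 `Cc1nc(-c2ccc(C(F)(F)F)cc2)sc1CNc1ccc(CCC(N)=O)cc1` — 12.9 nM

Both compounds were tested in a functional assay on CHO cells for agonist activity at Free fatty acid receptor 1 (Homo sapiens); on this read-out lower numbers stand for an effect already at smaller amounts and higher numbers for an effect only at larger amounts of compound. Compound 1 gives 145 nM, the higher of the two numbers; compound 2, which shares no single-point relationship with it, gives 12.9 nM, a gap that lies beyond the scatter of repeated measurements.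

Compound 3 `O=C(NO)[C@H]1C[C@@H]1c1ccc(NCc2cccc(Oc3ccccc3)c2)cc1` keeps the core of compound 1 and changes only one arm: 2-(hydroxycarbamoyl)cyclopropyl in place of 2-carboxyethenyl on an aromatic carbon. Within the data shown here, no measured pair shows what this exchange does, so any expectation rests on compound 1 alone and on the nature of the change. Because compound 1 already gives 145 nM, a moderate worsening is expected rather than a collapse. The expected step is a 2.8-fold higher number from compound 1 to compound 3 (0.44 log units; beyond the scatter), a move toward higher numbers that would exceed the scatter. Compound 3 is therefore estimated at 400 nM, within a range of 100 nM to 2000 nM.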

Compound 3, half-maximal effective concentration: 14.8 nM
Compound 3: the middle estimate sits 27-fold (1.43 log units) above what was measured, and the stated range ends above it.
By their numbers in this assay, from the lowest: compounds 2 and 3 (each within the scatter of the next); then compound 1.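

At this position, on an aromatic carbon para to a large group, the 2-carboxyethenyl arm turns out not to be needed for an effect at small amounts: in this assay, 2-(hydroxycarbamoyl)cyclopropyl in its place gives a 9.8-fold lower number from compound 1 to compound 3 (0.99 log units; beyond the scatter). This single exchange alters several things at once, since the new arm brings a three-membered carbon ring, two defined stereocentres and a hydroxycarbamoyl group. Nothing available explains why the number fell.

It remains open which part of the new arm accounts for the step: a carboxylic acid on the same cyclopropyl ring, or a hydroxycarbamoyl group on a two-carbon ethenyl link, would separate the ring from the hydroxycarbamoyl group. From the compounds shown here alone, the effect of the opposite arrangement at the two stereocentres also remains open.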